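This account rests on a few compounds, and the source may have more. Where it says the series, first, only, none or still open, it means among the compounds named here.

Notes on the series. Compound 1 `CC(C)[S+]([O-])CCCCN=C=S` and compound 2 `[O-][S+](CCCCN=C=S)Cc1ccccc1` carry the same chain ending in the isothiocyanate but differ in the group on the sulfur; the difference between the two cores is not broken down here. In a functional assay on SH-SY5Y cells (Homo sapiens) for cytotoxicity, read by MTT assay, with a stated time of 72 h (on this read-out lower numbers stand for stronger inhibition and higher numbers for weaker inhibition), compound 1 gives 9420 nM, and in this assay compound 2 gives 5210 nM. These two numbers lie within the scatter of each other, so no order is read into them.

Compound 3 `[O-][S+](CCCCCN=C=S)Cc1ccccc1` differs from compound 2 by a group of 4 heavy atoms (2 carbon, 1 nitrogen, 1 sulfur; no ring) in place of a group of 3 heavy atoms (1 carbon, 1 nitrogen, 1 sulfur; no ring), on a saturated chain carbon, four bonds along the chain from a sulfur. In this assay compound 3 gives 7010 nM. The step is a 1.3-fold higher number from compound 2 to compound 3 (0.13 log units; within the scatter), which is within the scatter: the longer chain leaves the read-out essentially where it was. Compound 3 and compound 1 also lie within the scatter of each other.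

Compound 4 `CC(C)[S+]([O-])CCCCCN=C=S` has not been measured. It differs from compound 1 by a group of 4 heavy atoms (2 carbon, 1 nitrogen, 1 sulfur; no ring) in place of a group of 3 heavy atoms (1 carbon, 1 nitrogen, 1 sulfur; no ring), on a saturated chain carbon, four bonds along the chain from a sulfur. The place of the change is the same word for word in both pairs, so this is the same change as that from compound 2 to compound 3, now made on the core of compound 1. For the measured compounds named here, only one measured instance of the change exists, so the expectation rests on it alone.

Compound 4 is expected to move by about a 1.2-fold higher number from compound 1 to compound 4 (0.09 log units; within the scatter). Going by the values given here, this rests on the one measured instance of the change, which gave a 1.3-fold higher number from compound 2 to compound 3 (0.13 log units; within the scatter). In this assay compound 4 is thus estimated at 11500 nM, with a likely range from 6500 nM to 20000 nM.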

Compound 4, half-maximal inhibitory concentration: 8620 nM
The estimate for compound 4 lay 1.3-fold (0.13 log units) above the measured number, and the stated range covers the measured number.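

In this assay the step on the core of compound 1 is a 1.1-fold lower number from compound 1 to compound 4 (0.04 log units; within the scatter) and stays within the scatter, so the extra chain carbon gives no readable step on this core either. Set beside the earlier instance, the same change on the two cores shows no difference beyond what repeated measurements allow: the same change on two cores in this assay, a 1.3-fold higher number (0.13 log units; within the scatter) from compound 2 to compound 3 and a 1.1-fold lower number (0.04 log units; within the scatter) from compound 1 to compound 4, 1.5-fold (0.17 log units) apart, within the scatter of two such steps. This supports only a limited statement, namely that on these two cores the group of 4 heavy atoms in place of the group of 3 heavy atoms gives no step beyond the scatter; since neither step can be told from the scatter, no direction or size of effect can be said to carry from one core to the other, and two instances do not establish a rule for the wider series.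

Open is whether a longer chain or a shorter chain on either core would give a step beyond the scatter, since the compounds shown cover only the two chain lengths of these pairs. Also open, on these data alone, is how the read-out would respond if a nitrile or an amine stood in place of the isothiocyanate at the end of the chain.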